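Swapping Methoxy for Methyl on a Shared Core

The compounds below may be only part of what the source reports. "The series", "measured", "known", "first", "only" and "open" are said of these compounds alone.

Three compounds built on one shared core differ only in the group carried on the attached benzene ring. Compound 1 `N#CC1=C(N)N2C(=O)CSC2=C(C#N)C1c1ccc(F)cc1` carries fluoro, compound 2 `N#CC1=C(N)N2C(=O)CSC2=C(C#N)C1c1ccc(Br)cc1` carries bromo, and compound 3 `COc1ccc(C2C(C#N)=C(N)N3C(=O)CSC3=C2C#N)cc1` carries methoxy. In a functional assay on HCT-116 cells (Homo sapiens) for inhibition, read by MTT assay, with a stated time of 48 h, tested at 1 mg/mL (a lower number here means less inhibition, a higher number more inhibition at the concentration tested (going by the name of the read-out)), compound 1 gives 47.8%, compound 2 gives 43.6%, and compound 3 gives 50.2%. Compound 3 shows the largest of the three numbers, yet a number 2.4 percentage points higher from compound 1 to compound 3 (within the scatter) and a number 6.6 percentage points higher from compound 2 to compound 3 (within the scatter) are both within the scatter, as is a number 4.2 percentage points lower from compound 1 to compound 2 (within the scatter), so the three compounds cannot be told apart on these numbers.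

Compound 4 `Cc1ccc(C2C(C#N)=C(N)N3C(=O)CSC3=C2C#N)cc1` continues this series with a single change: methyl in place of methoxy on an aromatic carbon. For the measured compounds named here, no measured step involves methyl, so the expectation rests on the three swaps already seen on this same aromatic carbon, each of which moved this assay by less than the scatter. A fourth exchange of one small group for another at the same place is therefore expected to behave the same way, giving a step of a number 3.2 percentage points lower from compound 3 to compound 4 (within the scatter), that is, none beyond the scatter. On that basis compound 4 is estimated to give 47% in this assay, with a range from 35% to 58%.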

Compound 4, a percentage reported as inhibition, at one concentration (the size of the read-out at that concentration, not a potency): 47.4%
The estimate for compound 4 lay 0.4 percentage points below the measured number, and the stated range covers the measured number.
By their numbers in this assay, from the lowest: compounds 2, 4, 1 and 3 (each within the scatter of the next).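

Exchanging methoxy for methyl takes away the oxygen and the hydrogen-bond acceptor counted for methoxy, yet this assay shows only a number 2.8 percentage points lower from compound 3 to compound 4 (within the scatter), and the exchanges from the two halogen compounds give a number 3.8 percentage points higher from compound 2 to compound 4 (within the scatter) and a number 0.4 percentage points lower from compound 1 to compound 4 (within the scatter). Methyl, a group of carbon alone, therefore joins fluoro, bromo and methoxy at this aromatic carbon, para to a large group, and every pair among the four compounds lies within the scatter, so no order among these groups can be read from this assay. No measurement at hand offers an explanation for this flat picture.

On these data alone, whether a different kind of group at this same place, such as an amine, a carboxylic acid or a longer chain, would move the number beyond the scatter stays open. These numbers also come from a single concentration, so they leave open how the four compounds would compare in potency, and they say nothing about changes elsewhere on the benzene ring or on the shared core.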